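This account rests on a few compounds, and the source may have more. Where it says the series, first, only, none or still open, it means among the compounds named here.

Within the data shown here, compound 2 `O=S(=O)(NCCCNCC1COc2ccccc2O1)c1cc(C(F)(F)F)cc(C(F)(F)F)c1` gives 2900 nM in a functional assay on ASPC1 cells (Homo sapiens) for inhibition, read by MTT assay, with a stated time of 72 h (on this read-out lower numbers stand for stronger inhibition of growth and higher numbers for weaker inhibition of growth), the lowest of the two numbers so far; compound 1 `O=S(=O)(NCCCNCc1ccccc1Cl)c1cc(C(F)(F)F)cc(C(F)(F)F)c1` gives 13000 nM. Compound 3 `O=S(=O)(NCCCNCc1ccc(Br)cc1)c1cc(C(F)(F)F)cc(C(F)(F)F)c1` differs from compound 2 by 4-bromophenyl in place of 2,3-dihydro-1,4-benzodioxin-2-yl on a saturated chain carbon bound to an amine nitrogen. Among the measured compounds shown here, the only measured step that bears on this, a 4.5-fold lower number from compound 1 to compound 2 (0.65 log units; beyond the scatter), concerns a change at the same place in the opposite direction, from a halogenated phenyl to the benzodioxin. A step of similar size upward in this assay is therefore expected here, a 2.8-fold higher number from compound 2 to compound 3 (0.44 log units; beyond the scatter). Compound 3 is estimated at 8000 nM, with a likely range from 3000 nM to 25000 nM.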

Compound 3, concentration for 50% growth inhibition: 2800 nM
Estimate against measurement, compound 3: 2.9-fold (0.46 log units) above, outside the stated range (below it).
By their numbers in this assay, from the lowest: compounds 3 and 2 (each within the scatter of the next); then compound 1.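

In this assay, among these compounds, the benzodioxin is not the only group at this place that goes with the lower numbers: 4-bromophenyl, with no hydrogen-bond acceptors, reads level with it (a 1.0-fold lower number from compound 2 to compound 3 (0.02 log units; within the scatter)). A halogenated phenyl therefore does not by itself give the high number of compound 1, since 4-bromophenyl in place of 2-chlorophenyl brings a clear change (a 4.6-fold lower number from compound 1 to compound 3 (0.67 log units; beyond the scatter)). No evidence is at hand to explain either step. From the compounds shown here alone, because the two phenyl groups differ in both halogen and its place, the effect of each stays open. A 4-chlorophenyl, a 2-bromophenyl or a plain phenyl would separate them.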